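The source may report more compounds than this note shows. Statements on the series, on what has been measured and on what is new or still open speak of the compounds shown alone.

The series rests on one shared core. Among the compounds with values here, compound 1 `CCc1ccc2nc(C(=O)Nc3c(F)cc(-c4cccc(F)c4)cc3F)c(C)c(C(=O)O)c2c1` is the first member, and in a functional assay on Hep 3B2 cells (Homo sapiens) for antiproliferative activity, read by MTT assay, with a stated time of 24 h, tested at 33.33 ug/mL (a lower number here means a weaker effect, a higher number a stronger effect of the compound at the concentration tested), compound 1 gives 36.3%. Compound 2 `Cc1c(C(=O)Nc2c(F)cc(-c3cccc(F)c3)cc2F)nc2ccc(F)cc2c1C(=O)O` differs from it by fluoro in place of ethyl on an aromatic carbon, and in this assay compound 2 gives 34.3%. Within the data shown here, the step of a number 2 percentage points lower from compound 1 to compound 2 (within the scatter) falls within the scatter, so on these two numbers compound 2 and compound 1 cannot be told apart, and compound 2 stands level with the only other compound measured. Compound 3 `COc1ccc2nc(C(=O)Nc3c(F)cc(-c4cccc(F)c4)cc3F)c(C)c(C(=O)O)c2c1` differs from compound 2 by methoxy in place of fluoro on an aromatic carbon. Among the measured compounds shown here, no measured step covers a methoxy entering in place of a fluoro. For the measured compounds named here, the single step available is the ethyl-to-fluoro exchange on the same core, and it was small, a number 2 percentage points lower from compound 1 to compound 2 (within the scatter), which offers no ground for a shift in either direction. A step in this assay beyond the scatter is therefore not expected for compound 3. Compound 3 is estimated at 35%, within a range from 20% to 50%, which corresponds to an expected step of a number 0.7 percentage points higher from compound 2 to compound 3 (within the scatter).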

Compound 3, a percentage reported as inhibition, at one concentration (the size of the read-out at that concentration, not a potency): 7.24%
Beside the measured number, compound 3's estimate is 27.8 percentage points above it, and the stated range ends above it.
By their numbers in this assay, from the lowest: compound 3; then compounds 2 and 1 (each within the scatter of the next).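

In this assay, methoxy on this aromatic carbon gives a number 27.1 percentage points lower from compound 2 to compound 3 (beyond the scatter) and, set against the ethyl of the first compound, a number 29.1 percentage points lower from compound 1 to compound 3 (beyond the scatter) so the position is not indifferent to what it carries, although the ethyl-to-fluoro exchange alone gave no sign of this. The methoxy group stands apart from both fluoro and ethyl, which remain level with each other, so the result separates one group from two others at a single carbon rather than ordering a graded series. The counts show that methoxy enters with a hydrogen-bond acceptor where fluoro has none, but nothing here ties the drop to that difference or to any other feature of the group, and no measured evidence bears on its cause.

With only three groups shown at this carbon, it remains open whether the weaker read-out belongs to methoxy alone or extends to a hydroxy, an ethoxy or an amine in the same place. On these data alone, each figure is also a read-out at one concentration, so how the three compounds compare in potency remains open as well.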